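The compounds below may be only part of what the source reports. "The series", "measured", "known", "first", "only" and "open" are said of these compounds alone.

Measured compounds in a functional assay on NFS-60 cells (Mus musculus) for antiproliferative activity, read by resazurin assay, with a stated time of 72 h; on this read-out higher numbers stand for weaker inhibition and lower numbers for stronger inhibition:

compound 1, `Cc1nc(-c2cnc(N3CCCC3)[nH]c2=O)ccc1Oc1ccnc(-c2cnn(C)c2)c1`: 56 nM
compound 2, `Cc1nc(-c2cnc(N3CCCCC3)[nH]c2=O)ccc1Oc1ccnc(-c2cnn(C)c2)c1`: 30 nM
compound 3, `Cc1nc(-c2cnc(NC3CCCC3)[nH]c2=O)ccc1Oc1ccnc(-c2cnn(C)c2)c1`: 2.6 nM

Among these three, compound 3 gives the lowest number, and both of its steps to the others are beyond the scatter: a 22-fold lower number from compound 1 to compound 3 (1.33 log units; beyond the scatter) and a 12-fold lower number from compound 2 to compound 3 (1.06 log units; beyond the scatter). The two compounds with a ring bonded through its own nitrogen lie close together, with a 1.9-fold lower number from compound 1 to compound 2 (0.27 log units; within the scatter); only the change to a ring attached through a separate amine nitrogen produced a large step.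

Compound 4, `Cc1nc(-c2cnc(NC3CCOCC3)[nH]c2=O)ccc1Oc1ccnc(-c2cnn(C)c2)c1`, has not yet been measured. It differs from compound 3 in one place: oxan-4-yl in place of cyclopentyl on a nitrogen on an aromatic ring. The amine nitrogen that sets compound 3 apart from compound 1 and compound 2 is kept; only the ring on it is exchanged. For the measured compounds named here, no measured step covers a swap of this kind, since the two large steps compare ring attachment, not ring identity, and the single step that compares ring size, from compound 1 to compound 2, lies within the scatter. A step of at most modest size is therefore expected in this assay, more likely toward a somewhat higher number than a lower one, and it may well stay within the scatter.

Compound 4 is therefore estimated at 5 nM, with a plausible range from 1.5 nM to 18 nM, meaning an expected step of a 1.9-fold higher number from compound 3 to compound 4 (0.28 log units; within the scatter).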

Compound 4, half-maximal inhibitory concentration: 413 nM
Compound 4: middle estimate off by 83-fold (1.92 log units), on the low side, outside the stated range (above it).
By their numbers in this assay, from the lowest: compound 3; then compounds 2 and 1 (each within the scatter of the next); then compound 4.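

For the compounds shown here, compound 4 shows that, in this assay, the ring on the amine nitrogen matters as well as the way the ring is attached: oxan-4-yl in place of cyclopentyl gives a 160-fold higher number from compound 3 to compound 4 (2.20 log units; beyond the scatter) and this step exceeds both large steps seen among the earlier compounds. Keeping the separate amine nitrogen is thus no guarantee of a low number, and compound 4 goes against the pattern suggested by compound 3, since (oxan-4-yl)amino in place of piperidin-1-yl gives a 14-fold higher number from compound 2 to compound 4 (1.14 log units; beyond the scatter) while in place of pyrrolidin-1-yl it gives a 7.4-fold higher number from compound 1 to compound 4 (0.87 log units; beyond the scatter) and so ends above both rings bonded through their own nitrogen. No measurement shown here accounts for these numbers.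

The change swaps a five-membered carbon ring for a six-membered ring carrying an oxygen, so ring size and the oxygen remain unseparated in these compounds. Cyclohexyl on the same amine nitrogen would keep the six-membered ring without the oxygen, and oxolan-3-yl would keep the oxygen in a five-membered ring, so each would test one of the two changes alone.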